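Swapping a Chloro for a Methoxy on the Fused Ring

The compounds below may be only part of what the source reports. "The series", "measured", "known", "first", "only" and "open" are said of these compounds alone.

Measured so far:
Compound 1, `COc1c(/C=C2/C(=O)Nc3ccccc32)c2ccccc2n1-c1ccccc1`: 1120 nM
Compound 2, `COc1c(/C=C2/C(=O)Nc3ccc(Cl)cc32)c2ccccc2n1-c1ccccc1`: 8510 nM

In a functional assay on cells (Cancer cell lines, Homo sapiens) for cytotoxicity, with a stated time of 48 h (on this read-out higher numbers stand for weaker inhibition of growth and lower numbers for stronger inhibition of growth), compound 1 gives 1120 nM, while compound 2 gives 8510 nM. Compound 2 therefore stands with the highest of the two numbers, and its nearest neighbour is compound 1, reached by a 7.6-fold higher number from compound 1 to compound 2 (0.88 log units; beyond the scatter), which came with chloro in place of hydrogen on an aromatic carbon.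

Compound 3, `COc1ccc2c(c1)/C(=C\c1c(OC)n(-c3ccccc3)c3ccccc13)C(=O)N2`, has not yet been measured. It differs from compound 2 by methoxy in place of chloro on an aromatic carbon. For the measured compounds named here, only one measured step touches the same position, namely a 7.6-fold higher number from compound 1 to compound 2 (0.88 log units; beyond the scatter), and it shows that a change there can move the number beyond the scatter. Going by the values given here, no measured step shows how a methoxy behaves at that position, so its direction is open; the values of compound 1 and compound 2 merely bracket what a small group at this carbon has done so far.

Compound 3 is therefore expected to fall between those two, with an estimated step of a 2.8-fold lower number from compound 2 to compound 3 (0.45 log units; beyond the scatter). The estimate for compound 3 is 3000 nM, with a range from 800 nM to 12000 nM.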

Compound 3, concentration for 50% growth inhibition: 2290 nM
Estimate against measurement, compound 3: 1.3-fold (0.12 log units) above; low and high end bracket the measured number.
By their numbers in this assay, from the lowest: compound 1; then compound 3; then compound 2.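

In this assay this aromatic carbon now carries a second group, and the outcome depends on which group it is: methoxy in place of chloro gives a 3.7-fold lower number from compound 2 to compound 3 (0.57 log units; beyond the scatter) and so takes back a good part of the rise seen with chloro. Set against plain hydrogen, methoxy still gives a 2.0-fold higher number from compound 1 to compound 3 (0.31 log units; beyond the scatter) and leaves compound 1 with the lowest number of the three, so neither substituent shown here improves on hydrogen. Among these three compounds, the carbon responds to which group sits on it and not merely to whether a group is present, although this rests on very few compounds and on this single carbon.

Whether an amine, a carboxylic acid or a longer chain such as ethoxy at this carbon could bring the number below that of compound 1 cannot be told from these compounds, and neither can whether fluoro would behave more like chloro or more like hydrogen. No separate measurement is available to say why methoxy and chloro differ here.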